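Swapping the anilide substituent in a weak cytotoxic series

This account rests on a few compounds, and the source may have more. Where it says the series, first, only, none or still open, it means among the compounds named here.

Compound 1 `CCc1cccc(NC(=O)c2cccc(/C=C3\CC(=O)N(Cc4ccccc4)C3=O)c2)c1` and compound 2 `CCCCCN1C(=O)C/C(=C\c2cccc(C(=O)Nc3cccc(CC)c3)c2)C1=O` share one core and differ only at the saturated chain carbon on the ring nitrogen. In an ADME assay on HCT-116 cells (Homo sapiens) for cytotoxicity, read by MTT assay, with a stated time of 72 h (on this read-out lower numbers stand for stronger inhibition and higher numbers for weaker inhibition), compound 1 gives 80600 nM, and compound 2 gives 75300 nM. Going by the values given here, the single measured step, a 1.1-fold lower number from compound 1 to compound 2 (0.03 log units; within the scatter), changes nothing beyond the scatter. Among the two measured numbers, compound 1 is the starting point here; compound 2, its nearest neighbour, lies within the scatter of it, so no order between the two is claimed.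

Compound 3 `CCOc1ccc(NC(=O)c2cccc(/C=C3\CC(=O)N(Cc4ccccc4)C3=O)c2)cc1` keeps the ring nitrogen of compound 1 unchanged and alters the other end of the molecule: 4-ethoxyphenyl in place of 3-ethylphenyl on an amide-type nitrogen. Among the compounds with values here, no measured step touches this amide-type nitrogen; the only step at hand concerns the saturated chain carbon on the ring nitrogen and gives no guide to the present change. With nothing bearing on it, compound 3 is expected to show a 1.0-fold lower number from compound 1 to compound 3 (0.00 log units; within the scatter), that is, no step beyond the scatter in either direction. Compound 3 is therefore estimated at 80000 nM, within a range of 30000 nM to 200000 nM.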

Compound 3, half-maximal inhibitory concentration: 41700 nM
Compound 3: middle estimate off by 1.9-fold (0.28 log units), on the high side; low and high end bracket the measured number.
By their numbers in this assay, from the lowest: compounds 3, 2 and 1 (each within the scatter of the next).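

The amide-type nitrogen, which the earlier step did not touch, now has a measured change of its own: in this assay the exchange of 3-ethylphenyl for 4-ethoxyphenyl gives a 1.9-fold lower number from compound 1 to compound 3 (0.29 log units; within the scatter). The entering group brings an oxygen and a hydrogen-bond acceptor that 3-ethylphenyl lacks, and among these three compounds neither this exchange nor the one at the saturated chain carbon on the ring nitrogen moves the number beyond the scatter, so both ends of the molecule have so far allowed a single change without a step that can be read as real. No measurement at hand offers an explanation for the size of this step.

The compounds shown leave open whether an amine, a carboxylic acid or a longer alkoxy chain on the aromatic ring at the amide-type nitrogen would produce a step beyond the scatter. Going by these compounds alone, they also leave open whether 4-ethoxyphenyl on the amide-type nitrogen would give a similar number when paired with the ring-nitrogen substituent of compound 2, since each change has been seen only on the core of compound 1.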